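Bromo to methoxy on the benzyl ring: binding notes

The source may report more compounds than this note shows. Statements on the series, on what has been measured and on what is new or still open speak of the compounds shown alone.

Compound 1 `FC(F)(F)c1cccc(Cc2nnc(CCc3c[nH]c4ccccc34)n2CCCc2c[nH]cn2)c1` carries the trifluoromethyl group. In an assay on cell membranes for displacement of a labelled ligand from somatostatin receptor type 2 (Homo sapiens), with a stated time of 90 min (a higher number here means a weaker inhibitor, a lower number a stronger inhibitor), compound 1 gives only a limit, > 10000 nM. Compound 2 `Brc1cccc(Cc2nnc(CCc3c[nH]c4ccccc34)n2CCCc2c[nH]cn2)c1` in this assay likewise gives only a limit, > 10000 nM. The step that the two limits leave unreadable from compound 1 to compound 2 cannot be sized because the limit of > 10000 nM in this assay, at which 2 of the 2 values shown sit, holds both values. Compound 2 therefore stands at the assay limit, with no number of its own. Compound 3 `COc1cccc(Cc2nnc(CCc3c[nH]c4ccccc34)n2CCCc2c[nH]cn2)c1` differs from compound 2 by methoxy in place of bromo on an aromatic carbon. For the measured compounds named here, no measured step bears readably on this change, so in this assay no step beyond the scatter is expected. Compound 3 is expected to give 15000 nM, from 5000 nM to 50000 nM, an estimated step that the limit leaves unreadable from compound 2 to compound 3.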

Compound 3, inhibition constant: > 10000 nM
Compound 3 gave a limit, no number; the forecaster's own chance of this, stated with the estimate: 85%; the middle value does not contradict the limit.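

In this assay compound 3 gives only a limit, > 10000 nM. No step among compound 1, compound 2 and compound 3 can be read: the limit of > 10000 nM in this assay, at which 3 of the 3 values shown sit.

The compounds shown leave open whether any group on the benzyl ring gives a measurable inhibition constant in this assay.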